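Reshuffling the Amino Alcohol Chain of Compound 3

The source may hold more compounds than are shown below. What is called first, only, known or untested is meant among the compounds shown, and "the series" means these compounds.

Of the compounds shown here, three sharing one core have been measured in a functional assay on SW480 cells (Homo sapiens) for inhibition; a lower number here means a stronger inhibitor, a higher number a weaker inhibitor. Compound 1 `COc1cc[nH]c1/C=C1\C(=O)Nc2ccc(F)c(C#C[C@H](C)O)c21` gives 400 nM. Compound 2 `COc1cc[nH]c1/C=C1\C(=O)Nc2ccc(F)c(C#CC(O)CN)c21` gives 110 nM. Compound 3 `CN[C@H](C#Cc1c(F)ccc2c1/C(=C/c1[nH]ccc1OC)C(=O)N2)CO` gives 100 nM. Compound 3 therefore sits with compound 2 at the low end of these numbers, the two being level within the scatter, while compound 1 stands clearly higher.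

Compound 4 `COc1cc[nH]c1/C=C1\C(=O)Nc2ccc(F)c(C#C[C@@H](N)[C@@H](C)O)c21`, not yet measured, has the same atoms as compound 3, joined differently, with 1-amino-2-hydroxypropyl in place of 2-hydroxy-1-(methylamino)ethyl on a triple-bonded carbon.

Two measured changes gave modest steps beyond the scatter, a 3.6-fold lower number from compound 1 to compound 2 (0.56 log units; beyond the scatter) and a 4.0-fold lower number from compound 1 to compound 3 (0.60 log units; beyond the scatter), and in both the chain gained an amino or methylamino group. Compound 4 keeps both an amino group and a hydroxyl, so those steps are not repeated here. Among the compounds with values here, the closest precedent is a 1.1-fold lower number from compound 2 to compound 3 (0.04 log units; within the scatter), within the scatter, where the chain was also rearranged. Within the data shown here, no measured step tests a chain with two defined stereocentres, which keeps the range wide.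

In this assay, no step beyond the scatter is expected, and the expected step is a 1.2-fold higher number from compound 3 to compound 4 (0.08 log units; within the scatter). For compound 4 the estimated value is 120 nM, with an expected range from 45 nM to 320 nM.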

Compound 4, half-maximal inhibitory concentration: 210 nM
Compound 4: the middle estimate sits 1.8-fold (0.24 log units) below what was measured, and the stated range covers the measured number.
By their numbers in this assay, from the lowest: compounds 3, 2, 4 and 1 (each within the scatter of the next, the first and the last beyond it).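

In this assay, the way the same atoms are joined in this chain matters on the triple-bonded carbon: putting 1-amino-2-hydroxypropyl in place of 2-hydroxy-1-(methylamino)ethyl gives a 2.1-fold higher number from compound 3 to compound 4 (0.32 log units; beyond the scatter), a modest step, whereas the earlier reshuffle from 2-amino-1-hydroxyethyl stayed within the scatter. Against the other two chains the picture is flatter, with a 1.9-fold higher number from compound 2 to compound 4 (0.28 log units; within the scatter) and a 1.9-fold lower number from compound 1 to compound 4 (0.28 log units; within the scatter), so an amino group and a hydroxyl in the chain do not by themselves secure the clear separation from 1-hydroxyethyl that compound 2 and compound 3 show. Nothing measured here explains why this rearrangement counts.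

Compound 4 differs from compound 3 both in how its chain is joined and in carrying a second defined stereocentre, so the compounds shown cannot say which of these goes with the step, and other stereoisomers of 1-amino-2-hydroxypropyl would be needed to separate the two. Also open, as far as these compounds go, is how this position would respond to a dimethylamino group or a longer chain such as 1-amino-2-hydroxybutyl.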